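Amine methylation and solubility across two cores

This account rests on a few compounds, and the source may have more. Where it says the series, first, only, none or still open, it means among the compounds named here.

Measured so far in a physicochemical assay for solubility, at pH 7.4; a lower number here means a less soluble compound, a higher number a more soluble compound:
compound 1, `CN(C)C1(C)CN(c2c(F)cc3c(=O)c(C(=O)O)cn(C4CC4)c3c2F)C1`, gives 23.6 ug/mL
compound 2, `CNC1(C)CN(c2c(F)cc3c(=O)c(C(=O)O)cn(C4CC4)c3c2F)C1`, gives 0.5 ug/mL
compound 3, `CN[C@H]1CN(c2cc3c(cc2F)c(=O)c(C(=O)O)cn3C2CC2)[C@@H]1C`, gives 9.2 ug/mL

Compound 1 and compound 2 share a core and differ in one place only, (methyl in place of hydrogen on an amine nitrogen). That change brought a 47-fold higher number from compound 2 to compound 1 (1.67 log units; beyond the scatter) in this assay. Compound 3 sits on a different core; the difference between the two cores is not broken down here. In this assay compound 3 stands second highest of the three, with compound 1 above it and compound 2 well below it.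

Compound 4, `C[C@@H]1[C@@H](N(C)C)CN1c1cc2c(cc1F)c(=O)c(C(=O)O)cn2C1CC1`, is not yet measured. It differs from compound 3 by methyl in place of hydrogen on an amine nitrogen, which is the same change as that between compound 2 and compound 1, at a place described in the same words. For the measured compounds named here, only one measured pair shows this change, and it lies on the other core, so its size on the core of compound 3 is not secured by a second example. Still, resting on the size of a 47-fold higher number from compound 2 to compound 1 (1.67 log units; beyond the scatter), a rise is expected, estimated as a 7.6-fold higher number from compound 3 to compound 4 (0.88 log units; beyond the scatter). Compound 4 is therefore expected to give about 70 ug/mL in this assay, with a plausible range from 15 ug/mL to 300 ug/mL.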

Compound 4, solubility: 96.3 ug/mL
Compound 4: the middle estimate sits 1.4-fold (0.14 log units) below what was measured, and the stated range covers the measured number.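

In this assay, methyl in place of hydrogen on an amine nitrogen gives a 10-fold higher number from compound 3 to compound 4 (1.02 log units; beyond the scatter) on this core, the same direction as a 47-fold higher number from compound 2 to compound 1 (1.67 log units; beyond the scatter) on the other core; both steps are large, so the change from methylamino to dimethylamino carried from one core to the other in this series. These two pairs do not fix the size of the step on any further core, and two examples do not amount to a general rule. Nothing shown here bears on why the number rises in either pair.

Open, from the compounds shown here alone, is whether a longer chain on the same amine nitrogen, such as ethyl in place of methyl, or a cyclic amine such as pyrrolidine, would follow the same direction on either core. Also open, going by these compounds, is whether the step would hold with an ester or an amide in place of the carboxylic acid that all four compounds carry.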